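The source may report more compounds than this note shows. Statements on the series, on what has been measured and on what is new or still open speak of the compounds shown alone.

Working notes on the selenium carbamate series.

Three compounds have been run so far in a functional assay on HTB-54 cells (Homo sapiens) for cytotoxicity, read by MTT assay, with a stated time of 72 h; on this read-out higher numbers stand for weaker inhibition of growth and lower numbers for stronger inhibition of growth. Compound 1 `CC(C)COC(=O)Nc1ccc([Se][Se]c2ccc(NC(=O)OCC(C)C)cc2)cc1` gives 52900 nM. Compound 2 `N#C[Se]c1ccc(NC(=O)Oc2ccc(F)cc2)cc1` gives 48400 nM. Compound 3 `C=CCOC(=O)Nc1ccc([Se]C#N)cc1` gives 50100 nM. Compound 3 stands second highest of the three numbers, but its nearest neighbour compound 2 and its furthest neighbour compound 1 both sit within the usual scatter of it, so the three values cannot be told apart on this read-out.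

The next compound, compound 4 `CC(C)COC(=O)Nc1ccc([Se]C#N)cc1`, keeps the selenocyanate-bearing core of compound 3 and changes only the carbamate chain: isopropyl in place of vinyl on a saturated chain carbon bound to an oxygen next to a carbonyl group.

Among the measured compounds shown here, nothing among the measured compounds shows how this kind of chain change moves the read-out; the three values already in hand are flat across quite different substituents. The expectation for compound 4 is therefore no step beyond the scatter, a 1.0-fold lower number from compound 3 to compound 4 (0.00 log units; within the scatter), in this assay. Compound 4 is estimated at 50000 nM, with a range from 25000 nM to 100000 nM.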

Compound 4, concentration for total growth inhibition: 51200 nM
The estimate for compound 4 lay 1.0-fold (0.01 log units) below the measured number; the measured number falls inside the stated range.
By their numbers in this assay, from the lowest: compounds 2, 3, 4 and 1 (each within the scatter of the next).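

In this assay, among the compounds shown here, this is the first comparison that differs in one place: isopropyl in place of vinyl on a saturated chain carbon bound to an oxygen next to a carbonyl group gives a 1.0-fold higher number from compound 3 to compound 4 (0.01 log units; within the scatter). The earlier values could not isolate any single change, whereas this pair shows that the change, including the loss of the double bond outside aromatic rings, does not separate the two compounds on this read-out. No measured evidence bears on this result.

Still open, on these data alone, is whether this position responds to a group of a different kind, such as an amine or a carboxylic acid at the end of the chain, or to a longer chain. The compounds shown also leave open whether any change here, with the shared core held fixed, can move the number beyond the scatter.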